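Compound 3 to compound 4: chloro for trifluoromethyl

The compounds below may be only part of what the source reports. "The series", "measured", "known", "first", "only" and "open" are said of these compounds alone.

In a functional assay (aorta) with Oryctolagus cuniculus as the target (on this read-out lower numbers stand for stronger inhibition and higher numbers for weaker inhibition), compound 1 `CCO/C(O)=C1\C(C)=NC(C)=C(C(=O)OCCCN2C(=O)c3ccccc3S2(=O)=O)C1c1ccccc1C(F)(F)F` gives 0.8 nM, compound 2 `COCCO/C(O)=C1\C(C)=NC(C)=C(C(=O)OCCCN2C(=O)c3ccccc3S2(=O)=O)C1c1ccccc1C(F)(F)F` gives 1.4 nM and compound 3 `CC1=NC(C)=C(C(=O)OCCCN2C(=O)c3ccccc3S2(=O)=O)C(c2ccccc2C(F)(F)F)/C1=C(\O)OCC1CCCO1` gives 3.7 nM. Compound 3 has the highest number of the three, with a 4.6-fold higher number from compound 1 to compound 3 (0.67 log units; beyond the scatter) and a 2.6-fold higher number from compound 2 to compound 3 (0.42 log units; beyond the scatter). Compound 4 `CC1=NC(C)=C(C(=O)OCCCN2C(=O)c3ccccc3S2(=O)=O)C(c2ccccc2Cl)/C1=C(\O)OCC1CCCO1` has chloro in place of trifluoromethyl on an aromatic carbon. The third measured step is a 1.8-fold higher number from compound 1 to compound 2 (0.24 log units; within the scatter). All three measured steps alter a saturated chain, so none tests this exchange directly, and they give only a general idea of step size in this series. No step beyond the scatter is therefore expected, and the estimate is a 1.1-fold lower number from compound 3 to compound 4 (0.02 log units; within the scatter). Compound 4 is estimated at 3.5 nM, with an expected range of 1.2 nM to 10 nM.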

Compound 4, half-maximal inhibitory concentration: 7.1 nM
For compound 4 the middle estimate is 2.0-fold (0.31 log units) below the measured one; the measured number falls inside the stated range.
By their numbers in this assay, from the lowest: compounds 1 and 2 (each within the scatter of the next); then compounds 3 and 4 (each within the scatter of the next).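

In this assay, chloro in place of trifluoromethyl on an aromatic carbon, ortho to a large group, gives a 1.9-fold higher number from compound 3 to compound 4 (0.28 log units; within the scatter). Among these compounds, this is the only reading at this aromatic carbon, as the earlier steps all alter a saturated chain, and it shows that one chlorine atom can replace the four heavy atoms of trifluoromethyl without a step beyond the scatter. No measurement available here accounts for the result.

Still open, on these data alone, is whether the same exchange stays within the scatter with the shorter ester chain of compound 1. Also open, as far as these compounds go, is how a nitro group or a methoxy group would read on this carbon.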